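Methyl for hydrogen at two places in one series

The compounds below may be only part of what the source reports. "The series", "measured", "known", "first", "only" and "open" are said of these compounds alone.

Compound 1 `CC(=O)NC1=NC(c2ccccc2)CN1` and compound 2 `CCC(=O)NC1=NC(c2ccccc2)CN1` share one core; compound 3 `COC(=O)NC1=NC(c2ccccc2)CN1C` and compound 4 `CCN1CC(c2ccccc2)N=C1NC(=O)OC` share another, and how the two cores differ is not broken down here. In a functional assay on the whole organism for antagonist activity, with Mus musculus as the target, in the maximal electroshock model (a higher number here means that more compound is needed for the effect, a lower number that less compound is needed), compound 1 gives 54 mg/kg and compound 2 gives 75 mg/kg. The change between them is methyl in place of hydrogen on a saturated chain carbon bound to a carbonyl carbon. The step is a 1.4-fold higher number from compound 1 to compound 2 (0.14 log units; within the scatter). In this assay compound 3 gives 107 mg/kg; set against compound 2 and compound 1 it lies within the scatter of both. Compound 4 is not yet measured; it differs from compound 3 by methyl in place of hydrogen on a saturated chain carbon bound to an amine nitrogen in a ring. The two places are not the same: in compound 2 the methyl sits on a saturated chain carbon bound to a carbonyl carbon, in compound 4 on a saturated chain carbon bound to an amine nitrogen in a ring, so this is the same kind of change, not the same one. The expectation rests on compound 3 with 107 mg/kg and on the size of a 1.4-fold higher number from compound 1 to compound 2 (0.14 log units; within the scatter): a step of about a 1.2-fold higher number from compound 3 to compound 4 (0.08 log units; within the scatter) is expected. Compound 4 is therefore expected to give 130 mg/kg in this assay, with a likely range from 60 mg/kg to 280 mg/kg.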

Compound 4, dose for half-maximal effect: 66 mg/kg
Compound 4: middle estimate off by 2.0-fold (0.29 log units), on the high side; the measured number falls inside the stated range.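

In this assay, methyl in place of hydrogen on a saturated chain carbon bound to an amine nitrogen in a ring gives a 1.6-fold lower number from compound 3 to compound 4 (0.21 log units; within the scatter), so this step alone shows no change in the amount of compound needed. Set beside the earlier methyl step on the core of compound 1, the new step does not separate from it, and within this single pair of steps the change carries from one core to the other without a detectable difference: the same change on two cores in this assay, a 1.4-fold higher number (0.14 log units; within the scatter) from compound 1 to compound 2 and a 1.6-fold lower number (0.21 log units; within the scatter) from compound 3 to compound 4, 2.3-fold (0.35 log units) apart, within the scatter of two such steps

Going by these compounds alone, this does not show that the change has a fixed size or direction on both cores, as each core offers only one step, the two steps sit at different places, and neither step can be read as a real shift.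

Open, as far as these compounds go, is whether a longer chain such as propyl, or a chain carrying an amine or a carboxylic acid, at either place would move the number beyond the scatter. Also open, from the compounds shown here alone, is how the change compares on both cores when made at one identical place.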